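The compounds below may be only part of what the source reports. "The series", "measured", "known", "first", "only" and "open" are said of these compounds alone.

Compound 1 `O=C(CSc1nc(Nc2ccccc2)c2ccccc2n1)Nc1cccc(Cl)c1`: 14300 nM
Compound 2 `O=C(CSc1nc(Nc2ccccc2)c2ccccc2n1)Nc1cccc(Br)c1`: 9620 nM
Compound 3 `C=CC(=O)Nc1cccc(NC(=O)CSc2nc(Nc3ccccc3)c3ccccc3n2)c1`: 7310 nM

These values come from a functional assay on MGC-803 cells (Homo sapiens) for inhibition, read by MTT assay, with a stated time of 72 h; on this read-out higher numbers stand for weaker inhibition and lower numbers for stronger inhibition. Compound 2 stands second highest of the three numbers, separated from compound 3 by a 1.3-fold lower number from compound 2 to compound 3 (0.12 log units; within the scatter) and from compound 1 by a 1.5-fold lower number from compound 1 to compound 2 (0.17 log units; within the scatter), both within the scatter. Compound 4 `O=C(CSc1nc(Nc2ccccc2)c2ccccc2n1)Nc1ccc(Br)cc1` has not been measured; it differs from compound 2 by 4-bromophenyl in place of 3-bromophenyl on an amide-type nitrogen. Going by the values given here, no measured step moves a group around that ring; each only exchanges one group for another, and every such exchange, a 1.5-fold lower number from compound 1 to compound 2 (0.17 log units; within the scatter), a 2.0-fold lower number from compound 1 to compound 3 (0.29 log units; within the scatter) and a 1.3-fold lower number from compound 2 to compound 3 (0.12 log units; within the scatter), stayed within the scatter. No step beyond the scatter is therefore expected. Compound 4 is estimated at 9600 nM, with a range from 4000 nM to 24000 nM. The expected step is a 1.0-fold lower number from compound 2 to compound 4 (0.00 log units; within the scatter).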

Compound 4, half-maximal inhibitory concentration: 19300 nM
The estimate for compound 4 lay 2.0-fold (0.30 log units) below the measured number; the measured number falls inside the stated range.
By their numbers in this assay, from the lowest: compounds 3, 2, 1 and 4 (each within the scatter of the next, the first and the last beyond it).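

Going by these compounds alone, this is the first step that moves a group around the ring instead of exchanging it: in this assay, 4-bromophenyl in place of 3-bromophenyl on the amide-type nitrogen gives a 2.0-fold higher number from compound 2 to compound 4 (0.30 log units; within the scatter) and so stays inside the usual scatter. The exchange of 3-chlorophenyl for 4-bromophenyl, with a 1.3-fold higher number from compound 1 to compound 4 (0.13 log units; within the scatter) also stays inside it. The series does now hold its first step beyond the scatter, a modest one, with a 2.6-fold higher number from compound 3 to compound 4 (0.42 log units; beyond the scatter) as the result.

Still open, from the compounds shown here alone, is how 4-aminophenyl or 4-methoxyphenyl would read in that place. Nothing measured here accounts for these numbers.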